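Naphthyloxyacetyl hydrazones: cytotoxicity toward a bromophenyl analogue

A few compounds are considered here, and "the series" means these few. Any claim that something is new, unique, unknown or untested is made for them only; others in the source may bear on it.

In an ADME assay on MT4 cells (Homo sapiens) for cytotoxicity, read by MTT assay, with a stated time of 4 days (on this read-out higher numbers stand for lower toxicity in this test and lower numbers for higher toxicity in this test), compound 1 `O=C(COc1cccc2ccccc12)N/N=C/C=C/c1ccccc1` gives 82.7 ug/mL, the highest of the three numbers measured. Compound 2 `C/C(=N\NC(=O)COc1cccc2ccccc12)c1ccccc1Br` gives 79.8 ug/mL in this assay, within the scatter of compound 1. Compound 3 `COc1cc(/C=N/NC(=O)COc2cccc3ccccc23)cc(OC)c1O` gives 16.3 ug/mL in this assay, a gap to compound 1 beyond the scatter. Compound 4 `O=C(COc1cccc2ccccc12)N/N=C/c1cccc(Br)c1` has not yet been measured. It differs from compound 1 by 3-bromophenyl in place of 2-phenylethenyl on a carbon with a double bond to nitrogen. Among the compounds with values here, no step between measured compounds matches this change; the nearest hint is compound 2, whose value 79.8 ug/mL with its bromophenyl group sits level with compound 1. The step from compound 1 to compound 4 is therefore expected to be a 1.1-fold lower number from compound 1 to compound 4 (0.06 log units; within the scatter), within the scatter. For compound 4 the estimated value is 72 ug/mL, with a range from 35 ug/mL to 150 ug/mL.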

Compound 4, half-maximal cytotoxic concentration: 87.4 ug/mL
For compound 4 the middle estimate is 1.2-fold (0.08 log units) below the measured one; the range from low to high includes it.
By their numbers in this assay, from the lowest: compound 3; then compounds 2, 1 and 4 (each within the scatter of the next).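

In this assay, 3-bromophenyl in place of 2-phenylethenyl on a carbon with a double bond to nitrogen gives a 1.1-fold higher number from compound 1 to compound 4 (0.02 log units; within the scatter), so this position accepts the exchange with no readable shift in the number. The double bond outside aromatic rings leaves with 2-phenylethenyl, and for this pair the read-out stays level without it. Nothing measured here bears on why the number holds. Still open, going by these compounds, is how an amine or a carboxylic acid in place of 3-bromophenyl would read on this carbon. On these data alone, a longer chain in place of 2-phenylethenyl also remains open.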